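The compounds below may be only part of what the source reports. "The series", "measured", "known", "first", "only" and "open" are said of these compounds alone.

Measured in a functional assay on HCT-116 cells (Homo sapiens) for antiproliferative activity, read by MTT assay, with a stated time of 72 h; on this read-out lower numbers stand for stronger inhibition and higher numbers for weaker inhibition:
- Compound 1 `CC(C)(C)c1ccc(OCCCON2C(N)=NC(N)=NC23CCSCC3)cc1`: 1 nM
- Compound 2 `NC1=NC2(CCSCC2)N(OCCCOc2cccc(Cl)c2Cl)C(N)=N1`: 1 nM
- Compound 3 `NC1=NC2(CCOCC2)N(OCCCOc2cccc(Br)c2)C(N)=N1`: 40 nM

Compound 2 stands level with compound 1 at the digits given, and the two share the lowest number in this small set. Compound 3 lies higher, beyond the scatter.

The next entry is compound 4 `NC1=NC2(CCSCC2)N(OCCCOc2cccc(Br)c2)C(N)=N1`, which keeps the core of compound 2 and differs in one place: 3-bromophenyl in place of 2,3-dichlorophenyl on an oxygen on a saturated carbon. That puts 3-bromophenyl in place of 2,3-dichlorophenyl on an oxygen on a saturated carbon.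

Among the measured compounds shown here, no measured pair isolates this change in this assay. Compound 1 at 1 nM and compound 2 at 1 nM show two different aryl-bearing ends on one core giving the same number. Compound 3 at 40 nM carries the same 3-bromophenyl on a different core, so its number cannot be read across directly. A small rise, possibly within the scatter, is expected.

The expected step is a 2.0-fold higher number from compound 2 to compound 4 (0.30 log units; within the scatter).

For compound 4 the estimated value is 2 nM, with an expected range of 0.6 nM to 10 nM.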

Compound 4, half-maximal inhibitory concentration: 1 nM
The estimate for compound 4 lay 2.0-fold (0.30 log units) above the measured number, and the stated range covers the measured number.
By their numbers in this assay, from the lowest: compounds 1, 2 and 4 (each within the scatter of the next); then compound 3.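

In this assay, among the compounds shown here, 3-bromophenyl in place of 2,3-dichlorophenyl on an oxygen on a saturated carbon gives no change at the digits printed from compound 2 to compound 4 (within the scatter) and is the first change at this position isolated on a single core, with these two aryl ends not separated by the read-out. The same 3-bromophenyl also links two compounds that differ only in the core, with compound 3 at 40 nM and compound 4 at 1 nM on the printed values, so within this pair the difference follows the core and not the aryl end. Nothing measured here explains either result.

Going by these compounds, whether the aryl end remains this permissive on the core of compound 3 stays open. Also open, on these data alone, is how the number responds to an amine or a carboxylic acid on the phenyl ring, or to a longer chain in place of the present one.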